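The source may report more compounds than this note shows. Statements on the series, on what has been measured and on what is new or still open speak of the compounds shown alone.

Of the compounds shown here, three with a shared core have been tested in an assay on HEK293 cells for activation of Kir3.1/Kir3.2 (Homo sapiens), read by thallium flux; a higher number here means a larger maximal response, a lower number a smaller maximal response. Compound 3 `Cc1cc(NC(=O)Cn2nnc(-c3ccc(Cl)c(Cl)c3)n2)n(C2CCCCC2)n1` gives 84% in this assay, the higher of the two numbers recorded. Compound 1 `Cc1cc(NC(=O)Cn2nnc(-c3ccccc3)n2)n(C2CCC(F)(F)CC2)n1` gives 68% in this assay, a number that falls short of compound 3 by more than the usual scatter. Compound 2 `Cc1nc(NC(=O)Cn2nnc(-c3ccccc3)n2)n(-c2ccccc2)n1` is reported in this assay as "not active" (no number reported), with no number attached.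

The next compound, compound 4 `Cc1cc(NC(=O)Cn2nnc(-c3ccccc3F)n2)n(C2CCCCC2)n1`, has not yet been measured. It differs from compound 3 in one place: 2-fluorophenyl in place of 3,4-dichlorophenyl on an aromatic carbon. Going by the values given here, no pair of measured compounds shows what this particular change does, so the step has to be estimated rather than read off. The expected step for compound 4 is a moderate fall, a number 22 percentage points lower from compound 3 to compound 4 (beyond the scatter), beyond the scatter. Compound 4 is therefore estimated to give 62% in this assay, with a range from 38% to 86%.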

Compound 4, largest response reached (Emax), in percent of the reference or control that the assay uses: 88%
The estimate for compound 4 lay 26 percentage points below the measured number; measured number outside the range, above it.
By their numbers in this assay, from the lowest: compound 1; then compounds 3 and 4 (each within the scatter of the next).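

In this assay, putting 2-fluorophenyl in place of 3,4-dichlorophenyl gives a number 4 percentage points higher from compound 3 to compound 4 (within the scatter), so the two groups cannot be told apart at this position. On the aromatic carbon of the five-membered ring with 4 nitrogen, a large maximal response therefore does not depend on the two chlorine atoms, since a phenyl ring carrying a single fluorine serves equally well in this pair. No measurement here explains why these two different groups give matching responses. From the compounds shown here alone, it remains open whether a phenyl ring with no added atom would hold the response on this same core, since compound 1 also differs elsewhere. Also open, going by these compounds, is how a phenyl ring carrying an amine or a carboxylic acid would behave at this position.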